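Stability notes: trimming the ether on compound 2

This account rests on a few compounds, and the source may have more. Where it says the series, first, only, none or still open, it means among the compounds named here.

Three compounds of the shared core have been run in an ADME assay on microsomes from liver (Homo sapiens) for metabolic stability, with a stated time of 60 min, tested at 1 uM; a lower number here means that less of the compound is left, a higher number that more of the compound is left. Compound 3 `COc1cc(-c2cnn3cc(OC)c(C(C)(C)O)nc23)ccn1` gives 66%; compound 1 `Cn1cc(-c2nc3c(-c4ccnc(OC5CC5)c4)cnn3cc2OCC(C)(C)O)cn1` gives 53%; compound 2 `COc1cn2ncc(-c3ccnc(OC(C)(C)C)c3)c2nc1-c1cnn(C)c1` gives 35%, the lowest of the three, with both gaps beyond the scatter. No pair among these three differs in only one place, so no single step has been measured. Compound 4 `COc1cn2ncc(-c3ccnc(OC(C)C)c3)c2nc1-c1cnn(C)c1` is the next entry and differs from compound 2 by hydrogen in place of methyl on a saturated chain carbon bound to an oxygen on an aromatic ring and two saturated chain carbons. For the measured compounds named here, no measured step speaks to this change, so only a small shift in this assay is expected, if any, most likely a modest rise. Compound 4 is estimated at 42%, within 28% to 58%, a step of a number 7 percentage points higher from compound 2 to compound 4 (within the scatter).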

Compound 4, percent of the compound remaining: 32%
Beside the measured number, compound 4's estimate is 10 percentage points above it; low and high end bracket the measured number.
By their numbers in this assay, from the lowest: compounds 4 and 2 (each within the scatter of the next); then compound 1; then compound 3.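

Read in this assay, tert-butoxy to isopropoxy is a number 3 percentage points lower from compound 2 to compound 4 (within the scatter), the first single-place step measured in this series. Taking one methyl off this saturated chain carbon does not separate compound 2 from compound 4, so this trim alone gives no measurable gain in the compound remaining. Nothing measured bears on the reason for this result.

From the compounds shown here alone, whether an amine or a difluoromethoxy group in place of the tert-butoxy would read differently stays open. Compound 1 and compound 3 differ from compound 2 in more than one place, so they do not settle this.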